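The source may report more compounds than this note shows. Statements on the series, on what has been measured and on what is new or still open speak of the compounds shown alone.

Measured so far:
- compound 1, `O=C(CCc1ccc(-c2ccccc2F)cc1)N1CCCC1`: 2800 nM
- compound 2, `O=C(CCCCCCc1ccc(O)cc1)N1CCCC1`: 5600 nM

Both were run in an assay on HEK293 cells for inhibition of N-acylethanolamine-hydrolyzing acid amidase (Rattus norvegicus), read by LC-MS, with a stated time of 30 min; on this read-out lower numbers stand for stronger inhibition and higher numbers for weaker inhibition. Compound 1 gives 2800 nM, the lower of the two numbers; compound 2 gives 5600 nM, but the gap between the two lies within the scatter of this assay, so no order between compound 1 and compound 2 can be read from these two values. Compound 2 also carries a different chain and a different end group, so it offers no single-change comparison to compound 1.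

The next compound, compound 3, `O=C(CCc1ccc(-c2ccsc2)cc1)N1CCCC1`, differs from compound 1 in one place: thiophen-3-yl in place of 2-fluorophenyl on an aromatic carbon. The change keeps the pyrrolidine amide and the three-carbon link to the shared core and exchanges only the group on the aromatic carbon para to the nine-heavy-atom group.

Among the compounds with values here, no measured step of this kind exists, so the expectation rests on the size of the exchange alone. The step from compound 1 to compound 3 is expected to be small, a 1.1-fold higher number from compound 1 to compound 3 (0.06 log units; within the scatter), not beyond the scatter in either direction. For compound 3 in this assay the estimate is 3200 nM, with a range from 1000 nM to 10000 nM.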

Compound 3, half-maximal inhibitory concentration: 2500 nM
Estimate against measurement, compound 3: 1.3-fold (0.11 log units) above; the measured number falls inside the stated range.
By their numbers in this assay, from the lowest: compounds 3, 1 and 2 (each within the scatter of the next, the first and the last beyond it).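

In this assay, thiophen-3-yl in place of 2-fluorophenyl gives a 1.1-fold lower number from compound 1 to compound 3 (0.05 log units; within the scatter) and so leaves the number within the scatter. The position para to a group of 9 heavy atoms therefore accepts a five-membered aromatic ring with 1 hetero atom and 5 heavy atoms in place of a six-membered aromatic ring of carbon only with 7 heavy atoms, without any difference that can be read in this assay; the exchange of fluorine and sulfur and the change in ring size cannot be separated in this single step. No measurement at hand gives a reason for this result.

From the compounds shown here alone, it remains open whether any group at this position moves the number beyond the scatter, which phenyl without fluorine, pyridin-3-yl, or a ring bearing an amine or a carboxylic acid could test. Going by these compounds, compound 2 differs from the other two compounds in more than one place, so the role of the chain also stays open until a longer chain is paired with 2-fluorophenyl or thiophen-3-yl on the shared core.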